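A few compounds are considered here, and "the series" means these few. Any claim that something is new, unique, unknown or untested is made for them only; others in the source may bear on it.

Compound 1 `Brc1ccccc1CSc1nnc(-c2ccncc2)n1-c1ccccc1`: 17100 nM in a functional assay on HepG2 cells (Homo sapiens) for inhibition, read by MTT assay, with a stated time of 48 h; on this read-out lower numbers stand for stronger inhibition and higher numbers for weaker inhibition
Compound 2 `Fc1ccc(CSc2nnc(-c3ccncc3)n2-c2ccccc2)cc1`: 15600 nM
Compound 3 `O=C(CSc1nnc(-c2ccncc2)n1-c1ccccc1)N/N=C/c1ccccc1`: 18600 nM

Compound 3 gives the highest of the three numbers, yet its distance to compound 1 and to compound 2 is within the scatter, so the three compounds cannot be told apart on this read-out. Within the data shown here, the only step between measured compounds, a 1.1-fold lower number from compound 1 to compound 2 (0.04 log units; within the scatter), concerns a halogen swap on a benzyl group and lies within the scatter as well.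

Compound 4 `O=C(CSc1nnc(-c2ccncc2)n1-c1ccccc1)N/N=C/c1cc(Br)cc(Br)c1O` differs from compound 3 in one place: 3,5-dibromo-2-hydroxyphenyl in place of phenyl on a carbon with a double bond to nitrogen. Among the measured compounds shown here, no measured step touches this position, and the one step seen, from compound 1 to compound 2, was flat; it bears on compound 4 only in showing that halogen changes elsewhere on the shared core moved nothing. The group entering carries a hydrogen-bond donor and acceptor that compound 3 lacks, which could shift the number in either direction. The expected step from compound 3 to compound 4 in this assay is therefore a modest lowering, a 1.6-fold lower number from compound 3 to compound 4 (0.19 log units; within the scatter), not clearly beyond the scatter. Compound 4 is estimated at 12000 nM, with a range from 4000 nM to 30000 nM.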

Compound 4, half-maximal inhibitory concentration: 7590 nM
For compound 4 the middle estimate is 1.6-fold (0.20 log units) above the measured one; the range from low to high includes it.
By their numbers in this assay, from the lowest: compound 4; then compounds 2, 1 and 3 (each within the scatter of the next).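

Among these compounds, until now this position had not been varied, and the single earlier step stayed within the scatter. In this assay, among the compounds shown here, the change on the carbon with a double bond to nitrogen gives a 2.5-fold lower number from compound 3 to compound 4 (0.39 log units; beyond the scatter) and is the first step here to exceed the scatter, which shows that the number responds to this position, if only modestly. No measurement bears on why the number falls with 3,5-dibromo-2-hydroxyphenyl in place of phenyl.

The hydroxy group and the bromines enter together, so the compounds shown do not say whether either alone would carry the step. Also open, on these data alone, is what an amine or a carboxylic acid on this phenyl ring would do to the number at this position.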